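Ethoxy homologation in the phthalimide-aminomethyl series

A few compounds are considered here, and "the series" means these few. Any claim that something is new, unique, unknown or untested is made for them only; others in the source may bear on it.

Compound 1 `Cc1ccc(NCN2C(=O)c3ccccc3C2=O)cc1` gives 54% in an assay on isolated protein for inhibition of ribosomal protein S6 kinase alpha-2 (Homo sapiens), read by fluorescence, with a stated time of 20 min, tested at 10 uM; on this read-out higher numbers stand for more inhibition at the one concentration tested (going by the name of the read-out) and lower numbers for less inhibition. Compound 2 `CCc1ccc(NCN2C(=O)c3ccccc3C2=O)cc1` gives 63% in this assay. The change between them is methyl in place of hydrogen on a saturated chain carbon bound to an aromatic carbon, and its step is a number 9 percentage points higher from compound 1 to compound 2 (within the scatter). Compound 3 `COc1ccc(NCN2C(=O)c3cccc(NC(=O)c4ccccc4)c3C2=O)cc1` gives 99.5% in this assay, the highest value of the three; the difference between the core of compound 3 and the core of compound 1 is not broken down here.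

Compound 4 `CCOc1ccc(NCN2C(=O)c3cccc(NC(=O)c4ccccc4)c3C2=O)cc1` has not been measured. It differs from compound 3 by methyl in place of hydrogen on a saturated chain carbon bound to an oxygen on an aromatic ring. This is the same kind of change as from compound 1 to compound 2, but the place is not identical: there the methyl enters on a saturated chain carbon bound to an aromatic carbon, here on a saturated chain carbon bound to an oxygen on an aromatic ring. Among the compounds with values here, the only measured step of this kind, from compound 1 to compound 2, lay within the scatter, so the expectation for compound 4 in this assay is a step of about a number 2.5 percentage points lower from compound 3 to compound 4 (within the scatter), resting on that earlier step and on the fact that compound 3 at 99.5% leaves almost no room upward on a read-out of inhibition at one concentration. Compound 4 is therefore estimated at 97%, with a range expected from 88% to 100%. The measurement will show whether the homologation at this different place behaves as the earlier one did.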

Compound 4, a percentage reported as inhibition, at one concentration (the size of the read-out at that concentration, not a potency): 105%
The estimate for compound 4 lay 8 percentage points below the measured number; the whole stated range lies below it.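

In this assay, within the data shown here, the change from methoxy to ethoxy reads a number 5.5 percentage points higher from compound 3 to compound 4 (within the scatter), so on the core of compound 3 this homologation gives no step that stands clear of the scatter. Set beside the earlier case, methyl in place of hydrogen reads alike on the two cores: the same change on two cores in this assay, a number 9 percentage points higher (within the scatter) from compound 1 to compound 2 and a number 5.5 percentage points higher (within the scatter) from compound 3 to compound 4, 3.5 percentage points apart, within the scatter of two such steps. This supports only a limited reading, that the change left the read-out within the scatter in both listed pairs; it does not show a gain that carries from core to core, and it does not establish that the two steps are equal, as the two places are not identical, the read-out comes from one concentration, and compound 3 and compound 4 both stand at the top of the scale, where a difference in potency could remain hidden.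

Open, on these data alone, are a longer chain on the oxygen, such as propoxy or butoxy, and an amine or a carboxylic acid in place of the ethoxy group on the core of compound 4. Also open, as far as these compounds go, is whether compound 3 and compound 4 would separate over a range of concentrations, and whether methoxy to ethoxy behaves in the same way on the core of compound 1.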